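A few compounds are considered here, and "the series" means these few. Any claim that something is new, unique, unknown or untested is made for them only; others in the source may bear on it.

Measured so far in a functional assay on HCC827 cells (Homo sapiens) for inhibition, read by fluorescence and resazurin assay, with a stated time of 72 h; on this read-out lower numbers stand for stronger inhibition of growth and higher numbers for weaker inhibition of growth:
- compound 1 `Nc1ccccc1-c1ccc(Nc2nc(N[C@H]3CC[C@H](N)CC3)nc3c2ncn3C2CCCC2)cc1`: 810 nM
- compound 2 `OCCCNc1nc(Nc2ccc(Oc3nccs3)cc2)c2ncn(C3CCCC3)c2n1`: 6490 nM

Of these two numbers, compound 1 holds the lower, and compound 2 lies above it by more than the usual scatter. Compound 1 is therefore the reference point for the next comparison.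

Compound 3 `N[C@H]1CC[C@H](Nc2nc(Nc3ccc(Oc4ncccn4)cc3)c3ncn(C4CCCC4)c3n2)CC1` has not yet been measured. It departs from compound 1 in one place: (pyrimidin-2-yl)oxy stands in place of 2-aminophenyl on an aromatic carbon of a six-membered aromatic ring of carbon only, para to a large group ((pyrimidin-2-yl)oxy in place of 2-aminophenyl on an aromatic carbon). The rest of compound 1 is kept.

Within the data shown here, no pair of measured compounds shows what this exchange does, so neither the size nor the direction of the step is supported by a measured precedent. In this assay, the working expectation is therefore no step beyond the scatter, anchored on compound 1 at 810 nM, with a wide margin on either side. The expected change is a 1.2-fold lower number from compound 1 to compound 3 (0.06 log units; within the scatter). For compound 3 the estimated value is 700 nM, with an expected range of 150 nM to 3000 nM.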

Compound 3, concentration for 50% growth inhibition: 2720 nM
For compound 3 the middle estimate is 3.9-fold (0.59 log units) below the measured one; the measured number falls inside the stated range.
By their numbers in this assay, from the lowest: compound 1; then compound 3; then compound 2.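

In this assay, among these compounds, this exchange gives the first measured step at this place, on an aromatic carbon of a six-membered aromatic ring of carbon only, para to a large group: a 3.4-fold higher number from compound 1 to compound 3 (0.53 log units; beyond the scatter). The read-out therefore responds to the group held here, even though 2-aminophenyl and (pyrimidin-2-yl)oxy have the same count of heavy atoms and neither carries a net charge, so heavy-atom count and net charge do not separate the pair; what differs is the oxygen, the ring type and the hydrogen-bond count, with 1 donor and 1 acceptor leaving and 0 donors and 3 acceptors entering. No measurement at hand assigns this step to any one of those differences.

The exchange alters several features at once, so the contribution of each remains unresolved; a plain phenyl would isolate the amine of 2-aminophenyl, and phenoxy would isolate the ring nitrogens of (pyrimidin-2-yl)oxy. As far as these compounds go, whether the step holds on other backbones also remains open, since compound 2 differs from compound 3 in more than one place and gives no matched comparison.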